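This account rests on a few compounds, and the source may have more. Where it says the series, first, only, none or still open, it means among the compounds named here.

Compound 2 `COc1ccc2nccc(C3CN(C4CCN(C)CC4)C(=O)O3)c2c1` carries a methyl on the ring amine nitrogen of the shared core. In an in vitro functional assay on RBL cells for antagonist activity at C-C chemokine receptor type 8 (Homo sapiens), read by FLIPR and calcium flux (on this read-out lower numbers stand for stronger inhibition and higher numbers for weaker inhibition), compound 2 gives only a limit, < 50200 nM, so where it stands is known no more closely than that (the limit of < 50200 nM in this assay, at which 1 of the 2 values shown sits). Compound 1 `COc1ccc2nccc(C3CN(C4CCN(Cc5ccc6ccccc6c5)CC4)C(=O)O3)c2c1`, which bears a naphthalen-2-yl on that same saturated chain carbon, gives 1260 nM in this assay. The step that the limit leaves unreadable from compound 1 to compound 2 therefore cannot be sized. Compound 3 `CCCCCCN1CCC(N2CC(c3ccnc4ccc(OC)cc34)OC2=O)CC1` differs from compound 2 by pentyl in place of hydrogen on a saturated chain carbon bound to an amine nitrogen in a ring. Going by the values given here, the only measured step that bears on this position is the one from compound 1, and since it is unreadable, the size of the change in this assay cannot be taken from it. Compound 3 is expected to land at 8000 nM, between 2000 nM and 40000 nM. The expected step is a step that the limit leaves unreadable from compound 2 to compound 3, though it cannot be checked against a limit.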

Compound 3, half-maximal inhibitory concentration: 501 nM
Compound 3: the middle estimate sits 16-fold (1.20 log units) above what was measured; measured number outside the range, below it.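

In this assay, pentyl in place of naphthalen-2-yl on a saturated chain carbon bound to an amine nitrogen in a ring gives a 2.5-fold lower number from compound 1 to compound 3 (0.40 log units; beyond the scatter). This position therefore does not need the naphthalen-2-yl for a measurable number: a chain with no ring serves here and gives the lower of the two numbers. Compound 2 gives only a limit, so the steps to and from it cannot be read, and the gain from the methyl to the hexyl stays unsized: the limit of < 50200 nM in this assay, at which 1 of the 3 values shown sits.

The compounds shown leave open how the number moves with chain length, which a butyl or an octyl at this position would begin to answer. They also leave open whether a phenyl or a hydroxyl at the end of the chain would keep, lower or raise the number.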